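The source may report more compounds than this note shows. Statements on the series, on what has been measured and on what is new or still open speak of the compounds shown alone.

Measured compounds:
Compound 1, `CCN(Cc1ccncc1)C(=S)SCc1ccc(C(=O)Nc2ccccc2N)cc1`: 86.2%
Compound 2, `CC1CCN(C(=S)SCc2ccc(C(=O)Nc3ccccc3N)cc2)CC1`: 87.4%
Compound 3, `CN(Cc1ccncc1)C(=S)SCc1ccc(C(=O)Nc2ccccc2N)cc1`: 86.1%

In a functional assay on A-375 cells (Homo sapiens) for antiproliferative activity, read by CCK-8 assay, with a stated time of 72 h, tested at 8 uM (a lower number here means a weaker effect, a higher number a stronger effect of the compound at the concentration tested), compound 3 gives 86.1%, and the steps of a number 0.1 percentage points lower from compound 1 to compound 3 (within the scatter) and a number 1.3 percentage points lower from compound 2 to compound 3 (within the scatter) both lie within the scatter, so the three measured compounds stand together with no separation between them. Compound 4, `CN(Cc1cccnc1)C(=S)SCc1ccc(C(=O)Nc2ccccc2N)cc1`, differs from compound 3 by pyridin-3-yl in place of pyridin-4-yl on a saturated chain carbon bound to an amide-type nitrogen. Among the compounds with values here, no measured step moves the ring nitrogen of the pyridinyl group itself. The steps that alter the groups on the thiocarbonyl carbon, a number 1.2 percentage points higher from compound 1 to compound 2 (within the scatter) and a number 0.1 percentage points lower from compound 1 to compound 3 (within the scatter), were within the scatter, which suggests this region tolerates change without a shift beyond the scatter. Compound 4 is therefore expected to show a number 1.1 percentage points lower from compound 3 to compound 4 (within the scatter). The estimate for compound 4 is 85%, within a range from 75% to 93%.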

Compound 4, a percentage reported as inhibition, at one concentration (the size of the read-out at that concentration, not a potency): 83.8%
For compound 4 the middle estimate is 1.2 percentage points above the measured one; measured number inside the range.
By their numbers in this assay, from the lowest: compounds 4, 3, 1 and 2 (each within the scatter of the next).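

In this assay, within the data shown here, the exchange of pyridin-4-yl for pyridin-3-yl on a saturated chain carbon bound to an amide-type nitrogen (a number 2.3 percentage points lower from compound 3 to compound 4 (within the scatter)) is the first step to swap these two pyridinyl groups, and it stays within the scatter. The wider changes on the thiocarbonyl carbon (a number 3.6 percentage points lower from compound 2 to compound 4 (within the scatter); a number 2.4 percentage points lower from compound 1 to compound 4 (within the scatter)) also stay within the scatter, so compound 4 stands together with the other three. No evidence is available that bears on this result. The compounds shown leave open whether pyridin-2-yl or a plain phenyl group in this place would stay with the others. A reading at a single concentration also leaves open whether the effects of these compounds would stay together at any other concentration.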